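The source may report more compounds than this note shows. Statements on the series, on what has been measured and on what is new or still open speak of the compounds shown alone.

Series notes, displacement at adenosine receptor A3.

Compound 1 `Cc1nc(N)c2nn(Cc3ccccc3)cc2n1` gives 1% in an assay on CHO cells for displacement of a labelled ligand from adenosine receptor A3 (Homo sapiens), read by scintillation counting, with a stated time of 60 min, tested at 1 uM; a lower number here means less inhibition, a higher number more inhibition at the concentration tested (going by the name of the read-out). Among the measured compounds shown here, compound 2 `Nc1nc(Cc2ccccc2)nc2cn(Cc3ccccc3)nc12` gives 15% in this assay; the step of a number 14 percentage points higher from compound 1 to compound 2 (beyond the scatter) is the single measured step in the set. Compound 2 therefore stands highest of the two numbers recorded so far, with compound 1 as its nearest neighbour.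

The next compound, compound 3 `Nc1nc(-c2ccco2)nc2cn(Cc3ccccc3)nc12`, differs from compound 2 as follows: furan-2-yl in place of benzyl on an aromatic carbon. For the measured compounds named here, no measured step covers this change; the only step available concerns a different position and a different group, so it bears on the prediction only indirectly. Nothing in the two numbers shows what the exchange of benzyl for furan-2-yl on the aromatic carbon does.

Compound 3 is estimated to give 12% in this assay, within 0% to 35%. Going by the values given here, the expected step of a number 3 percentage points lower from compound 2 to compound 3 (within the scatter) is within the scatter, since compound 2 at 15% gives little room and no step supports a directional expectation.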

Compound 3, a percentage reported as inhibition, at one concentration (the size of the read-out at that concentration, not a potency): 2%
Beside the measured number, compound 3's estimate is 10 percentage points above it; the range from low to high includes it.
By their numbers in this assay, from the lowest: compounds 1 and 3 (each within the scatter of the next); then compound 2.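

At this aromatic carbon, between two ring nitrogen atoms, replacing the benzyl gives a number 13 percentage points lower from compound 2 to compound 3 (beyond the scatter) in this assay, so a small gain seen with benzyl does not carry over to every aromatic group here. Against the methyl of the core of compound 1, furan-2-yl gives a number 1 percentage points higher from compound 1 to compound 3 (within the scatter), so the furan-2-yl ring adds nothing that can be told apart from methyl. Of the three groups shown, only benzyl stands apart from the other two, and it does so by a modest margin. Nothing available explains this difference between the groups.

Open, as far as these compounds go, is whether the saturated carbon of benzyl matters, which phenyl attached directly to this carbon would test, or whether a longer chain such as phenethyl would raise the number further. From the compounds shown here alone, an amine at this carbon, and any change to the other benzyl group on the core, also remain open.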